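A few compounds are considered here, and "the series" means these few. Any claim that something is new, unique, unknown or untested is made for them only; others in the source may bear on it.

Working notes on the series. Compound 1 `O=C1C=C(Nc2ccc(I)cc2)C(=O)c2c1nc1n2[C@H]2OC[C@@H](O)[C@H]2OC1`, compound 2 `O=C1C(Nc2cccc(Cl)c2)=CC(=O)c2c1nc1n2[C@H]2OC[C@@H](O)[C@H]2OC1` and compound 3 `O=C1C=C(Nc2ccc(C(F)(F)F)cc2)C(=O)c2c1nc1n2[C@H]2OC[C@@H](O)[C@H]2OC1` share one core and differ only in the group carried on the amine nitrogen. In a functional assay on MCF7 cells (Homo sapiens) for inhibition, read by sulforhodamine B assay (a lower number here means a stronger inhibitor, a higher number a weaker inhibitor), compound 1 gives 2230 nM. In this assay compound 2 gives 2970 nM. For compound 3 the this assay reports only a limit, > 4000 nM, as noted in the limit of > 4000 nM in this assay, at which 1 of the 3 values shown sits. For the measured compounds named here, the only step that can be sized, an at least 1.7-fold higher number from compound 1 to compound 3 (0.25 log units; that floor lies within the scatter), is accordingly itself a floor. Among the two plain numbers in this assay compound 2 stands highest; its nearest neighbour is compound 1, and that gap lies within the scatter, so no order between them is claimed.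

Compound 4 `O=C1C(NCc2ccccc2)=CC(=O)c2c1nc1n2[C@H]2OC[C@@H](O)[C@H]2OC1` is not yet measured. It differs from compound 2 as follows: benzyl in place of 3-chlorophenyl on an amine nitrogen. Going by the values given here, no measured step bears directly on this: an at least 1.7-fold higher number from compound 1 to compound 3 (0.25 log units; that floor lies within the scatter) swaps one substituent for another on an aromatic carbon, while an aromatic ring stays bound to the nitrogen in compounds 1, 2 and 3; benzyl on that nitrogen is untested. The expected step in this assay is therefore a 1.3-fold higher number from compound 2 to compound 4 (0.11 log units; within the scatter), a drift not clearly beyond the scatter, with a wide band. Compound 4 is estimated at 3800 nM, between 1500 nM and 10000 nM.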

Compound 4, half-maximal inhibitory concentration: > 8000 nM
Compound 4: a limit, no number (the forecaster's own chance of this, stated with the estimate: 45%); middle value at least 2.1-fold (0.32 log units) from the limit.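

The change from 3-chlorophenyl to benzyl on this amine nitrogen gives the only step shown in this assay that lies beyond the scatter, an at least 2.6-fold higher number from compound 2 to compound 4 (0.43 log units; beyond the scatter), so what is bound to this nitrogen matters and not only what the aromatic ring carries. On these data alone, that step is a floor and its full size remains unknown, since compound 4 carries a limit and not a number: the limit of > 8000 nM in this assay, at which 1 of the 4 values shown sits. Reaching a limit does not set benzyl apart from the compounds with the ring bound directly to the nitrogen, as compound 3 also carries one, and no order can be read between those two limits.

The change removes the chlorine and also places a carbon between the ring and the nitrogen, and the compounds shown do not separate these two parts, which an unsubstituted phenyl or a 3-chlorobenzyl group on the same nitrogen would begin to do. Also open, as far as these compounds go, is how this position responds to groups without an aromatic ring, such as a simple alkyl chain, or to a longer link such as 2-phenylethyl.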